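This account rests on a few compounds, and the source may have more. Where it says the series, first, only, none or still open, it means among the compounds named here.

Compound 1 `O=C(Nc1ccc(-c2nc3ccccc3s2)cc1)C(Cl)Cl`: > 100 nM, a limit
Compound 2 `O=C(Nc1ccc(-c2nc3ccccc3s2)cc1)C(F)(F)F`: > 100 nM, a limit

In a functional assay on MDA-MB-468 cells (Homo sapiens) for antiproliferative activity (a higher number here means a weaker inhibitor, a lower number a stronger inhibitor), compound 2 gives > 100 nM, which is a limit of the assay and not a number. The same holds for both compounds measured: the limit of > 100 nM in this assay, at which 2 of the 2 values shown sit. For the measured compounds named here, the only measured step, a step that the two limits leave unreadable from compound 1 to compound 2, has no readable size, so it offers no guide to the next change. Compound 3 `C/C(S)=N/c1ccc(-c2nc3ccccc3s2)cc1` replaces the ((trifluoromethyl)carbonyl)amino group on an aromatic carbon: a group of 4 heavy atoms (2 carbon, 1 nitrogen, 1 sulfur; no ring) in place of a group of 7 heavy atoms (2 carbon, 1 nitrogen, 1 oxygen, 3 fluorine; no ring), on an aromatic carbon. Going by the values given here, with no sized step to draw on, the direction in this assay remains open, and only a weak expectation is possible. The expected step is a step that the limit leaves unreadable from compound 2 to compound 3. For compound 3 the estimate is 300 nM, within an expected range of 40 nM to 2000 nM.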

Compound 3, half-maximal inhibitory concentration: > 100 nM
Compound 3: no number, only a limit; the forecaster's own chance of this, stated with the estimate: 60%; the middle value does not contradict the limit.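

In this assay, for the compounds shown here, compound 3 gives > 100 nM, a limit and not a number, so no step among compound 1, compound 2 and compound 3 can be read. The compounds shown leave open how strongly any of them inhibits, and whether these changes matter at all, because all share one result: the limit of > 100 nM in this assay, at which 3 of the 3 values shown sit.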